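Aryl swap on the alkyne: compound 2 to compound 3

This account rests on a few compounds, and the source may have more. Where it says the series, first, only, none or still open, it means among the compounds named here.

Compound 2 `CNC(=O)[C@@]12C[C@@H]1[C@@H](n1cnc3c(NC)nc(C#Cc4ccc(CO)cc4)nc31)[C@H](O)[C@@H]2O` gives 16% in an assay on CHO cells for displacement of a labelled ligand from adenosine receptor A1 (Homo sapiens), read by scintillation counting, with a stated time of 60 min, tested at 10 uM (a lower number here means less inhibition, a higher number more inhibition at the concentration tested (going by the name of the read-out)), the larger of the two numbers shown, yet its gap to compound 1 `CNC(=O)[C@@]12C[C@@H]1[C@@H](n1cnc3c(NC)nc(C#Cc4ccccc4OC)nc31)[C@H](O)[C@@H]2O` stays within the scatter; compound 1 gives 12% in this assay. Among the compounds with values here, the one measured step, a number 4 percentage points higher from compound 1 to compound 2 (within the scatter), exchanged the aryl group on the triple-bonded carbon without moving the read-out beyond the scatter. Compound 3 `CNC(=O)[C@@]12C[C@@H]1[C@@H](n1cnc3c(NC)nc(C#Cc4cccnc4)nc31)[C@H](O)[C@@H]2O` carries the change (pyridin-3-yl in place of 4-(hydroxymethyl)phenyl on a triple-bonded carbon). On that single precedent, the expected step is a number 2 percentage points lower from compound 2 to compound 3 (within the scatter), none beyond the scatter. Compound 3 is therefore estimated at 14%, within 4% to 26%.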

Compound 3, a percentage reported as inhibition, at one concentration (the size of the read-out at that concentration, not a potency): 16%
Beside the measured number, compound 3's estimate is 2 percentage points below it; the measured number falls inside the stated range.
By their numbers in this assay, from the lowest: compounds 1, 2 and 3 (each within the scatter of the next).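

In this assay the step of no change at the digits printed from compound 2 to compound 3 (within the scatter) for pyridin-3-yl in place of 4-(hydroxymethyl)phenyl and the step of a number 4 percentage points higher from compound 1 to compound 3 (within the scatter) for pyridin-3-yl in place of 2-methoxyphenyl extend the position on the triple-bonded carbon to a six-membered aromatic ring with a hetero atom, and the read-out does not move beyond the scatter. Losing the hydrogen-bond donor of 4-(hydroxymethyl)phenyl likewise leaves no step beyond the scatter. No supporting data explain this flat read-out.

On these data alone, whether an amine, a carboxylic acid or a longer chain on the triple-bonded carbon would give a step beyond the scatter remains open.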